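From 2-Phenylethenyl to 2-(4-Methylphenyl)ethyl on the Shared Core

The compounds below may be only part of what the source reports. "The series", "measured", "known", "first", "only" and "open" are said of these compounds alone.

Compound 1 `Cc1cc(-c2nc(C(F)(F)F)ccc2CNC(=O)C(C)c2ccc(NS(C)(=O)=O)c(F)c2)ccc1F` gives 0.4 nM in an assay on CHO cells for antagonist activity at transient receptor potential cation channel subfamily V member 1 (Homo sapiens), read by FLIPR; a higher number here means a weaker inhibitor, a lower number a stronger inhibitor.
Compound 2 `CC(C(=O)NCc1ccc(C(F)(F)F)nc1Cc1ccccc1)c1ccc(NS(C)(=O)=O)c(F)c1` gives 141 nM in this assay.
Compound 3 `CC(C(=O)NCc1ccc(C(F)(F)F)nc1/C=C/c1ccccc1)c1ccc(NS(C)(=O)=O)c(F)c1` gives 2.2 nM in this assay.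

Among these three, compound 3 holds the second highest number: compound 1 sits below it by a 5.5-fold higher number from compound 1 to compound 3 (0.74 log units; beyond the scatter), while compound 2 sits far above it by a 64-fold lower number from compound 2 to compound 3 (1.81 log units; beyond the scatter). Compound 4 `Cc1ccc(CCc2nc(C(F)(F)F)ccc2CNC(=O)C(C)c2ccc(NS(C)(=O)=O)c(F)c2)cc1` has not yet been measured. It differs from compound 3 in one place: 2-(4-methylphenyl)ethyl in place of 2-phenylethenyl on an aromatic carbon.

Among the measured compounds shown here, two measured steps bear on this change. The step from the flexible benzyl of compound 2 to the 2-phenylethenyl of compound 3 was large, a 64-fold lower number from compound 2 to compound 3 (1.81 log units; beyond the scatter), and the step from the directly attached 4-fluoro-3-methylphenyl of compound 1 to the same 2-phenylethenyl was modest, a 5.5-fold higher number from compound 1 to compound 3 (0.74 log units; beyond the scatter). For the measured compounds named here, the group entering in compound 4 has no double bond outside aromatic rings, which places it closer to the benzyl of compound 2 than to the 2-phenylethenyl of compound 3, though it is one carbon longer and carries a methyl; no measured pair tests either of those features. Compound 4 is therefore expected to give a higher number than compound 3 in this assay, a step of roughly an 18-fold higher number from compound 3 to compound 4 (1.26 log units; beyond the scatter), though smaller than the full gap to compound 2. The estimate for compound 4 is 40 nM, with a range from 6 nM to 250 nM.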

Compound 4, inhibition constant: 0.6 nM
Compound 4: the middle estimate sits 67-fold (1.82 log units) above what was measured; measured number below the stated range.
By their numbers in this assay, from the lowest: compounds 1 and 4 (each within the scatter of the next); then compound 3; then compound 2.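

In this assay the step to the saturated chain runs the other way from a loss, a 3.7-fold lower number from compound 3 to compound 4 (0.56 log units; beyond the scatter), so a double bond outside aromatic rings is not required for a low number at this position when 2-(4-methylphenyl)ethyl is the group that enters. The benzyl of compound 2 marks a poor end of the series, with a 240-fold lower number from compound 2 to compound 4 (2.37 log units; beyond the scatter), and a low number therefore does not follow from any saturated link to the phenyl ring; meanwhile a 1.5-fold higher number from compound 1 to compound 4 (0.18 log units; within the scatter) places the directly attached 4-fluoro-3-methylphenyl and the 2-(4-methylphenyl)ethyl on level terms in this assay. Nothing given here explains why the saturated group performs as it does.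

The compounds shown leave open whether the longer chain or the added methyl accounts for the difference between compound 2 and compound 4, a question that the plain 2-phenylethyl group would address. They also leave open how far the chain can be extended at this position, for example to 3-phenylpropyl, or whether an amine can stand in the chain.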